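Dropping the carboxy-bearing ring from compound 1

The source may report more compounds than this note shows. Statements on the series, on what has been measured and on what is new or still open speak of the compounds shown alone.

Values measured so far in (a physicochemical assay for lipophilicity; on this read-out lower numbers stand for lower lipophilicity and higher numbers for higher lipophilicity)
- compound 1 (`C[C@H]1CN(c2ncc(C(=O)Nc3nc(-c4cccc(C(F)(F)F)c4F)cs3)cc2Cl)CC1C(=O)O`) gives 2.79 in this read-out
- compound 2 (`O=C(Nc1nc(-c2cccc(C(F)(F)F)c2F)cs1)c1ccc(N2CCC(C(=O)O)CC2)nc1`) gives 1.83 in this read-out

Compound 1 stands highest of the two measured compounds in (this assay). Compound 2 lies lower, and the gap between them is beyond the scatter. The next compound to be read is compound 3 (`O=C(Nc1nc(-c2cccc(C(F)(F)F)c2F)cs1)c1cnc(N2CCCCC2)c(Cl)c1`), which has no number yet.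

Compound 3 keeps the core of compound 1 and has piperidin-1-yl in place of 3-carboxy-4-methylpyrrolidin-1-yl on an aromatic carbon. The site lies next to the ring nitrogen and ortho to a chloro group.

Among the compounds with values here, no measured pair that differs in one place is available to size this change. Both measured compounds carry a carboxy group, compound 1 at (2.79) and compound 2 at (1.83), while compound 3 has none, so neither value covers a compound without it. A large upward step, well beyond the scatter, is expected (a number 2.41 log units higher from compound 1 to compound 3 (beyond the scatter)). For compound 3 the expected value is 5.2 within an estimated range (4.3 to 6).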

Compound 3, distribution coefficient: 7.1
The estimate for compound 3 lay 1.90 log units below the measured number; the whole stated range lies below it.
By their numbers in this assay, from the lowest: compound 2; then compound 1; then compound 3.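

At the aromatic carbon next to the ring nitrogen and ortho to a chloro group, the group carried there has a very large bearing on the read-out: in this assay, piperidin-1-yl in place of 3-carboxy-4-methylpyrrolidin-1-yl gives a number 4.31 log units higher from compound 1 to compound 3 (beyond the scatter), with the rest of the structure unchanged. Within the data shown here, this is the first step in the set that isolates a single site, so the size of a change at this carbon can now be read directly rather than inferred from compounds that differ in more than one place. The change is a bundle, however, since the hydrogen-bond donor, the stereocentre and the five-membered ring all leave together, and nothing available here explains the size of the step.

This single step cannot divide its size among the carboxylic acid, the methyl group and the ring size, a question that a plain pyrrolidin-1-yl or a 4-carboxypiperidin-1-yl at this carbon, with the chloro group kept, would begin to answer. It also leaves open how other groups at this carbon, such as morpholin-4-yl or a primary amine, would sit relative to compound 3 in this assay.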